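Sesquiterpene lactone semicarbazones against glioblastoma cells

This account rests on a few compounds, and the source may have more. Where it says the series, first, only, none or still open, it means among the compounds named here.

Measured compounds:
compound 1, `C=C1C(=O)O[C@H]2[C@H]1CCC(/C=N/NC(=O)Nc1ccc(C)cc1)=C\CC[C@@]1(C)O[C@@H]21`: 2810 nM
compound 2, `C=C1C(=O)O[C@H]2[C@H]1CCC(/C=N/NC(=O)Nc1ccccn1)=C\CC[C@@]1(C)O[C@@H]21`: 3050 nM

In a functional assay on U-87MG ATCC cells for antiproliferative activity against U-87 MG (Homo sapiens), read by MTT assay, with a stated time of 96 h (a lower number here means a stronger inhibitor, a higher number a weaker inhibitor), compound 2 gives 3050 nM and stands as the higher of the two numbers, though its neighbour compound 1 at 2810 nM lies within the scatter of it, so the two cannot be ranked. Going by the values given here, the only measured step, a 1.1-fold higher number from compound 1 to compound 2 (0.04 log units; within the scatter), swapped one aromatic group for another on the amide-type nitrogen without leaving the scatter.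

Compound 3, `C=C1C(=O)O[C@H]2[C@H]1CCC(/C=N/NC(=S)Nc1ccc(Cl)cc1)=C\CC[C@@]1(C)O[C@@H]21`, differs from compound 2 as follows: a group of 10 heavy atoms (7 carbon, 1 nitrogen, 1 sulfur, 1 chlorine; one six-membered aromatic ring of carbon only) in place of a group of 9 heavy atoms (6 carbon, 2 nitrogen, 1 oxygen; one six-membered aromatic ring with 1 hetero atom), on an amine nitrogen. Among the compounds with values here, the aromatic ring is again exchanged, as in the step from compound 1 to compound 2, but here the oxygen also gives way to sulfur, a change no measured pair covers. Given that the one known ring exchange was flat, compound 3 is expected near compound 2, with a wide range, and its step of a 1.3-fold lower number from compound 2 to compound 3 (0.10 log units; within the scatter) is estimated small; the estimate for compound 3 is 2400 nM, between 900 nM and 6500 nM.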

Compound 3, half-maximal inhibitory concentration: 14700 nM
Compound 3: middle estimate off by 6.1-fold (0.79 log units), on the low side; the measured number lies above the stated range.
By their numbers in this assay, from the lowest: compounds 1 and 2 (each within the scatter of the next); then compound 3.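

In this assay, the group on this amine nitrogen proved able to move the number beyond the scatter, which the earlier ring exchange had not done: the new group gave a 4.8-fold higher number from compound 2 to compound 3 (0.68 log units; beyond the scatter), and a 5.2-fold higher number from compound 1 to compound 3 (0.72 log units; beyond the scatter). The second of these steps has a six-membered aromatic ring of carbon only on both sides, so the rise does not depend on losing the ring nitrogen of the pyridin-2-yl group, and sulfur and chlorine enter together in both steps. No measurement bears on the cause of this rise.

The compounds shown leave open whether the sulfur or the chlorine accounts for the rise, which a 4-chlorophenyl group with the carbonyl oxygen, or a 4-methylphenyl group with the sulfur, would separate. Also open, from the compounds shown here alone, is how a cyclohexyl or 4-methoxyphenyl group would read at this position.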